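Acetamido replacing cyclopropylamino on the ring nitrogen of compound 1

A few compounds are considered here, and "the series" means these few. Any claim that something is new, unique, unknown or untested is made for them only; others in the source may bear on it.

Measured so far:
- compound 1, `COc1c(NS(=O)(=O)c2ccc(F)cc2)cc(-c2ccc3nc(NC4CC4)sc3n2)cc1C(N)=O`: 33100 nM
- compound 2, `COc1c(NS(=O)(=O)c2ccc(F)cc2)cc(-c2ccc3nc(NC(=O)C4CC4)sc3c2)cc1C(N)=O`: 1580 nM
- compound 3, `NC(=O)c1cc(NS(=O)(=O)c2ccc(F)cc2)cc(-c2ccc3nc(NC(=O)C4CC4)sc3c2)c1`: "not determined" (no result reported)

In a functional assay on MCF7 cells (Homo sapiens) for antiproliferative activity, read by MTT assay, with a stated time of 72 h (on this read-out higher numbers stand for weaker inhibition and lower numbers for stronger inhibition), compound 1 gives 33100 nM, the highest number of the two that are known. Compound 2 gives 1580 nM, a gap beyond the scatter; compound 2 differs from compound 1 at the core as well as at the amine, so the gap cannot be assigned to one place. Compound 3 gives "not determined" (no result reported), so no number is known for it. Compound 4 is `COc1c(NS(=O)(=O)c2ccc(F)cc2)cc(-c2ccc3nc(NC(C)=O)sc3n2)cc1C(N)=O`; it differs from compound 1 as acetyl in place of cyclopropyl on a nitrogen on an aromatic ring. Among the measured compounds shown here, no measured pair isolates this change. Given that compound 2 carries an acyl on the same nitrogen, compound 4 is expected to give a lower number, a step of a 3.3-fold lower number from compound 1 to compound 4 (0.52 log units; beyond the scatter) beyond the scatter. Compound 4 is therefore estimated at 10000 nM, within 2500 nM to 40000 nM.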

Compound 4, half-maximal inhibitory concentration: 12500 nM
The estimate for compound 4 lay 1.3-fold (0.10 log units) below the measured number; the measured number falls inside the stated range.
By their numbers in this assay, from the lowest: compound 2; then compound 4; then compound 1.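

In this assay the change from cyclopropylamino to acetamido gives a 2.6-fold lower number from compound 1 to compound 4 (0.42 log units; beyond the scatter) on an otherwise unchanged structure, the only pair shown that differs at this nitrogen alone. The number therefore responds to the group on this nitrogen, though the step is modest and the value stays high. Nothing measured here accounts for the step. Open, as far as these compounds go, is whether a longer acyl chain such as propionyl, or an unsubstituted amine on the same nitrogen, would move the number further on this core.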